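Deacetylation of a sesquiterpene lactone: from acetate to free alcohol

The source may report more compounds than this note shows. Statements on the series, on what has been measured and on what is new or still open speak of the compounds shown alone.

Measured so far in a functional assay on HL-60 cells (Homo sapiens) for cytotoxicity, read by MTT assay, with a stated time of 72 h; on this read-out lower numbers stand for stronger inhibition and higher numbers for weaker inhibition:
compound 1 `CC(=O)O[C@@H]1CC(C)=C(CCC2=CC(=O)OC2)[C@@]2(C)CCCC(C)(C)[C@H]12` gives < 5 ug/mL, which is a limit of the assay.
compound 2 `CC(=O)O[C@@H]1C[C@@H](C)[C@](O)(CCC2=CC(=O)OC2)[C@@]2(C)CCCC(C)(C)[C@H]12` gives < 5 ug/mL, again a limit.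
compound 3 `CC1=C(CC[C@@H](C)C(=O)CCC2=CC(=O)OC2)C(C)(C)CCC1` gives < 5 ug/mL, also a limit.

Compound 2 thus sits where every value shown sits, at the limit of < 5 ug/mL in this assay, at which 3 of the 3 values shown sit, so nothing separates it from the other two. Compound 4 `C[C@@H]1C[C@@H](O)[C@H]2C(C)(C)CCC[C@]2(C)[C@@]1(O)CCC1=CC(=O)OC1` is not yet measured. It differs from compound 2 by hydrogen in place of acetyl on an oxygen on a saturated carbon. Within the data shown here, no measured pair shows the effect of such a change here, so no size of step is known. The step that the limit leaves unreadable from compound 2 to compound 4 is expected to stay within the usual scatter. For compound 4 the expected value is 4 ug/mL, estimated between 1 ug/mL and 15 ug/mL.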

Compound 4, half-maximal inhibitory concentration: < 5 ug/mL
Compound 4: no number, only a limit; the forecaster's own chance of this, stated with the estimate: 60%; the middle value lies beyond the limit too.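

Among these compounds, no step from compound 2 to compound 4 can be read, because both compounds sit at a limit: the limit of < 5 ug/mL in this assay, at which 4 of the 4 values shown sit.

In this assay the compounds shown leave open how far going from acetoxy to hydroxy shifts the value, and how the four compounds rank.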